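The compounds below may be only part of what the source reports. "The series", "measured", "known", "first", "only" and "open" are said of these compounds alone.

Compound 1 `CCCCCCCCc1ccc(OCC(=O)Cn2nnc(C)n2)cc1`: < 5%
Compound 2 `CCCCCCCCc1ccc(OCC(=O)Cn2nnnc2C)cc1`: 32%
Compound 3 `CCCCCCCCc1ccc(OCC(=O)Cn2nnnc2-c2ccccc2)cc1`: 36%

These three compounds were measured in an ADME assay on S9 fraction from liver (Rattus norvegicus) for metabolic stability, read by LC-MS, using NADPH, with a stated time of 30 min; on this read-out higher numbers stand for a more stable compound and lower numbers for a less stable compound. For compound 1, the entry < 5% is a limit of the assay and not a number. Compound 3 gives 36%, level within the scatter with compound 2 at 32%.

Compound 4 `CCCCCCCCc1ccc(OCC(=O)Cn2nnnc2-c2ccccc2Cl)cc1` differs from compound 3 by a single change: chloro in place of hydrogen on an aromatic carbon. The closest measured comparison is a number 4 percentage points higher from compound 2 to compound 3 (within the scatter), where phenyl replaced methyl on an aromatic carbon. The other measured step, a number at least 27 percentage points higher from compound 1 to compound 2 (beyond the scatter), was much larger, but it swapped 5-methyl-2H-tetrazol-2-yl for 5-methyl-1H-tetrazol-1-yl and so concerns a different place in the molecule. With only the small step of a number 4 percentage points higher from compound 2 to compound 3 (within the scatter) as a guide on the aromatic side, no clear direction can be expected in this assay. The expected change is a number 1 percentage points lower from compound 3 to compound 4 (within the scatter), which would not go beyond the scatter. Compound 4 is expected at 35%, with an estimated range from 18% to 52%.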

Compound 4, percent of the compound remaining: 42%
Compound 4: the middle estimate sits 7 percentage points below what was measured; low and high end bracket the measured number.
By their numbers in this assay, from the lowest: compounds 2, 3 and 4 (each within the scatter of the next). At a limit, below all of these: compound 1.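

In this assay, among the compounds shown here, the change from phenyl to 2-chlorophenyl is the first test of a substituent on this aromatic ring, and it gives a number 6 percentage points higher from compound 3 to compound 4 (within the scatter). Compared with the methyl group of compound 2, the 2-chlorophenyl group gives a number 10 percentage points higher from compound 2 to compound 4 (within the scatter), so compounds 2, 3 and 4 cannot be told apart here, and chloro at this place, ortho to a large group, brings no loss beyond the scatter. Nothing among the measurements shown bears on what lies behind this result.

As far as these compounds go, it remains open whether chloro on another carbon of this ring would give a similar number. From the compounds shown here alone, it is also open whether an amine or a carboxylic acid in place of chloro, or a hexyl chain in place of the octyl chain, would move the number beyond the scatter.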